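This account rests on a few compounds, and the source may have more. Where it says the series, first, only, none or still open, it means among the compounds named here.

- compound 1 `CCCCc1nc(C(C)C)c(CC(=O)OC2CC2)c(=O)n1Cc1ccc(-c2ccccc2-c2noc(=O)[nH]2)cc1` with 11.4% measured
- compound 2 `CCCCc1nc(C)c(CC(=O)OC(C)C)c(=O)n1Cc1ccc(-c2ccccc2-c2noc(=O)[nH]2)cc1` with 4% measured

In an ADME assay on microsomes from liver (Mus musculus) for metabolic stability, with a stated time of 30 min (on this read-out higher numbers stand for a more stable compound and lower numbers for a less stable compound), compound 2 at 4% stands within the scatter of compound 1 at 11.4% and so neither ranks above the other. Compound 3 `CCCCc1nc(C)c(CC(=O)OCC2CCCCC2)c(=O)n1Cc1ccc(-c2ccccc2-c2noc(=O)[nH]2)cc1` has not been measured and differs from compound 2 by cyclohexylmethyl in place of isopropyl on an oxygen next to a carbonyl group with cyclohexylmethyl in place of isopropyl on an oxygen next to a carbonyl group. Going by the values given here, no measured pair shows this change alone, so the expectation in this assay is for no step beyond the scatter and no firm direction. The estimated move is a number 2 percentage points higher from compound 2 to compound 3 (within the scatter) and stays small. For compound 3 the estimate is 6% with an expected range from 1% to 18% in repeat measurements.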

Compound 3, percent of the compound remaining: 8.9%
For compound 3 the middle estimate is 2.9 percentage points below the measured one; the measured number falls inside the stated range.
By their numbers in this assay, from the lowest: compounds 2, 3 and 1 (each within the scatter of the next).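

Going by these compounds alone, compound 3 gives the first comparison that changes only one place, on an oxygen next to a carbonyl group. In this assay, cyclohexylmethyl in place of isopropyl gives a number 4.9 percentage points higher from compound 2 to compound 3 (within the scatter), so adding the six-membered non-aromatic ring does not separate the two compounds on this read-out. Nothing available explains this result. Still open, on these data alone, is whether a carboxylic acid at this place, or a longer chain ending in an amine, would give a step beyond the scatter. As far as these compounds go, whether this change behaves alike on the core of compound 1 is also open.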